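Amide change from compound 1 to compound 3

The compounds below may be only part of what the source reports. "The series", "measured", "known", "first", "only" and "open" are said of these compounds alone.

Measured in an ADME assay on HepG2 cells (Homo sapiens) for cytotoxicity, in the presence of a further agent that is not named here; on this read-out lower numbers stand for stronger inhibition and higher numbers for weaker inhibition:
- compound 1 `Cn1c(Cc2ccccc2C(F)(F)F)nc(C(=O)Nc2ccccc2)c(O)c1=O`: > 100000 nM
- compound 2 `COc1c(C(=O)NCc2ccccc2)nc(Cc2ccccc2C(F)(F)F)n(C)c1=O`: > 100000 nM

Compound 1 gives > 100000 nM in this assay, and this is a limit of the assay and not a number. Compound 2 gives > 100000 nM, which is likewise a limit. Among the measured compounds shown here, compound 1 therefore has no exact position on the scale, and the only reading available for the series is the limit of > 100000 nM in this assay, at which 2 of the 2 values shown sit.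

Compound 3 `Cn1c(Cc2ccccc2C(F)(F)F)nc(C(=O)NCc2ccccc2F)c(O)c1=O` remains to be measured. It carries 2-fluorobenzyl in place of phenyl on an amide-type nitrogen, with the rest of the core of compound 1 unchanged: 2-fluorobenzyl in place of phenyl on an amide-type nitrogen.

For the measured compounds named here, no measured pair provides a step to work from, so the expectation rests on compound 1 alone, whose > 100000 nM is a limit. The expected step of a number no higher from compound 1 to compound 3 (the limit leaves the size open) is none beyond the scatter, and no direction is assigned to it. A result reported only as a limit again is the more likely outcome. For compound 3 the estimated value is 100000 nM, with an expected range of 50000 nM to 200000 nM.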

Compound 3, half-maximal inhibitory concentration: > 100000 nM
Compound 3: no number, only a limit; the forecaster's own chance of this, stated with the estimate: 75%; the middle value sits exactly at the limit.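

In this assay compound 3 gives > 100000 nM as a limit and not a number. Among the compounds shown here, compound 1 is also reported only as a limit, so no step from compound 1 to compound 3 can be read: the limit of > 100000 nM in this assay, at which 3 of the 3 values shown sit.

Whether 2-fluorobenzyl in place of phenyl on the amide-type nitrogen shifts the value in this assay stays open, as does the exact position of these compounds on the scale.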